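A Trifluoromethyl Step Repeated on a Second Core

The source may hold more compounds than are shown below. What is called first, only, known or untested is meant among the compounds shown, and "the series" means these compounds.

Compound 1 `FC(F)(F)c1ccc(NCc2cn(-c3ccccc3)nc2-c2ccc(C(F)(F)F)cc2)cc1` and compound 2 `FC(F)(F)c1ccc(NCc2cn(-c3ccccc3)nc2-c2ccccc2)cc1` share one core and differ by trifluoromethyl in place of hydrogen on an aromatic carbon. In an ADME assay on MDBK cells (Bos taurus) for cytotoxicity, read by MTT assay, with a stated time of 72 h (a lower number here means that less compound is tolerated, a higher number that more compound is tolerated), compound 2 gives 34000 nM, and compound 1 gives 26000 nM, so this change made a 1.3-fold lower number from compound 2 to compound 1 (0.12 log units; within the scatter). Compound 3 `Cc1ccc(-c2nn(-c3ccccc3)cc2CNc2ccccc2)cc1` is built on a different core; the difference between the two cores is not broken down here. In this assay compound 3 gives only a limit, > 100000 nM, rather than a number. It therefore stands at the limit of > 100000 nM in this assay, at which 1 of the 3 values shown sits. Compound 4 `Cc1ccc(-c2nn(-c3ccccc3)cc2CNc2ccc(C(F)(F)F)cc2)cc1` carries the core of compound 3 and differs from it by trifluoromethyl in place of hydrogen on an aromatic carbon, the same change as that between compound 2 and compound 1, at the same place on the ring. Since on the first core the change made a 1.3-fold lower number from compound 2 to compound 1 (0.12 log units; within the scatter), compound 4 is expected to show a number no higher from compound 3 to compound 4 (the limit leaves the size open) in this assay. For compound 4 the value is estimated at 100000 nM, with a range from 50000 nM to 200000 nM, and a reading that is again only a limit would not be surprising.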

Compound 4, half-maximal cytotoxic concentration: > 100000 nM
Compound 4: no number, only a limit; the forecaster's own chance of this, stated with the estimate: 60%; the middle value sits exactly at the limit.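

In this assay compound 4 gives > 100000 nM, which is a limit and not a number, and compound 3 is only a limit as well, so the step between them cannot be read. Within the data shown here, the trifluoromethyl change therefore can be said neither to carry over to the second core nor to fail there, and a 1.3-fold lower number from compound 2 to compound 1 (0.12 log units; within the scatter) remains its only reading. The steps that can be read are an at least 2.9-fold higher number from compound 2 to compound 4 (0.46 log units; beyond the scatter) and an at least 3.8-fold higher number from compound 1 to compound 4 (0.58 log units; beyond the scatter), but these are methyl changes, one in place of hydrogen and one in place of trifluoromethyl, and neither isolates the trifluoromethyl change on the second core: the limit of > 100000 nM in this assay, at which 2 of the 4 values shown sit.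

The compounds shown leave open what numbers compound 3 and compound 4 would give if they could be read below the limit of the assay. They also leave open how an amine or a carboxylic acid in place of the trifluoromethyl would read on either core.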